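Swapping a Fluoropyridine for a Chlorophenyl on the Sulfonyl

A few compounds are considered here, and "the series" means these few. Any claim that something is new, unique, unknown or untested is made for them only; others in the source may bear on it.

Of the compounds shown here, three built on one shared core have been tested in a functional assay on DLD-1 cells (Homo sapiens) for antiproliferative activity, read by CellTiter-Glo, with a stated time of 72 h; a lower number here means a stronger inhibitor, a higher number a weaker inhibitor. Compound 1 `CC1CCN(C2CCN(S(=O)(=O)c3cccc(C(F)(F)F)c3)CC2)CC1` gives > 5000 nM in this assay, which is a limit of the assay rather than a number. Compound 2 `CC1CCN(C2CCN(S(=O)(=O)c3cccnc3Cl)CC2)CC1` gives > 5000 nM in this assay, again only a limit. Compound 3 `CC1CCN(C2CCN(S(=O)(=O)c3cccnc3F)CC2)CC1` gives > 5000 nM in this assay, also a limit. Going by the values given here, the one measured step, a step that the two limits leave unreadable from compound 2 to compound 3, therefore has no readable size. All three values sit at the same place, (the limit of > 5000 nM in this assay, at which 3 of the 3 values shown sit), so compound 3 stands at that limit with no number to set it apart from the others.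

Compound 4 `CC1CCN(C2CCN(S(=O)(=O)c3cccc(Cl)c3)CC2)CC1` has not yet been measured. It differs from compound 3 in one place: 3-chlorophenyl in place of 2-fluoropyridin-3-yl on a sulfonyl sulfur. Among the compounds with values here, no measured step can be sized, so none gives a direction for this change; every value so far, including that of compound 1 at > 5000 nM, is a limit. Compound 4 is thus expected to give about 10000 nM, within 4000 nM to 30000 nM, most probably reported again as a limit. The expected step is a step that the limit leaves unreadable from compound 3 to compound 4, nothing beyond the scatter.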

Compound 4, half-maximal inhibitory concentration: > 5000 nM
Compound 4 ended at the assay's limit; the forecaster's own chance of this, stated with the estimate: 85%; the middle value does not contradict the limit.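

Compound 4 also gives only a limit of the assay, so no step among compound 1, compound 2, compound 3 and compound 4 can be read: the limit of > 5000 nM in this assay, at which 4 of the 4 values shown sit.

The compounds shown leave open whether any group on the sulfonyl sulfur would give a readable value in this assay.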